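Aminopropyl in place of hydrogen: expected inhibition of compound 3

The source may report more compounds than this note shows. Statements on the series, on what has been measured and on what is new or still open speak of the compounds shown alone.

Working notes on the series. Compound 1 `CC(C)C[C@@H]1NC(=O)[C@H](C)NC1=O` and compound 2 `CC(C)C[C@@H]1NC(=O)[C@H](CCC(=O)O)NC1=O` share one core and differ only in a side chain. In a functional assay, tested at 2.5 mM (a lower number here means less inhibition, a higher number more inhibition at the concentration tested (going by the name of the read-out)), compound 1 gives 0%, and compound 2 gives 0%. The single measured step, no change at the digits printed from compound 1 to compound 2 (within the scatter), leaves compound 1 level with compound 2 at the digits shown, within the scatter.

Compound 3 `CC(C)C[C@@H]1NC(=O)[C@H](CCCCN)NC1=O` is not yet measured. Its difference from compound 1 is 3-aminopropyl in place of hydrogen on a saturated chain carbon bound to a saturated ring carbon. Within the data shown here, the only measured step at this place is no change at the digits printed from compound 1 to compound 2 (within the scatter), which showed no change beyond the scatter, so no step beyond the scatter is expected here either, in either direction. Compound 3 is therefore expected to give about 2% in this assay, with a range of -5% to 12%. The estimated step is a number 2 percentage points higher from compound 1 to compound 3 (within the scatter), expected to stay within the scatter.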

Compound 3, a percentage reported as inhibition, at one concentration (the size of the read-out at that concentration, not a potency): 0%
Compound 3: middle estimate off by 2 percentage points, on the high side; the measured number falls inside the stated range.
By their numbers in this assay, from the lowest: compounds 1, 2 and 3 (each within the scatter of the next).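

In this assay, 3-aminopropyl in place of hydrogen on a saturated chain carbon bound to a saturated ring carbon gives no change at the digits printed from compound 1 to compound 3 (within the scatter), so this position has now been probed with a chain ending in an amine as well as one ending in a carboxylic acid. Exchanging the chain end, 2-aminoethyl in place of carboxy, gives no change at the digits printed from compound 2 to compound 3 (within the scatter), so this assay does not separate these two chain ends at this position. No supporting data bear on why the read-out stays flat.

From the compounds shown here alone, whether a phenyl ring, an imidazole or a guanidine on this chain would give any inhibition stays open. With no inhibition to compare against, the compounds shown also leave open whether changes elsewhere on the shared core would matter.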